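Notes on an ester-to-amide step in the series

The source may report more compounds than this note shows. Statements on the series, on what has been measured and on what is new or still open speak of the compounds shown alone.

Three compounds have numbers in an assay on isolated protein for inhibition of Gonadotropin-releasing hormone receptor (Rattus norvegicus); a lower number here means a stronger inhibitor, a higher number a weaker inhibitor. Compound 1 `CCn1c(SCc2cc([N+](=O)[O-])ccc2OC)nc2cc(NC(=O)NC(C)(C)C)ccc21` gives 170 nM. Compound 2 `COc1ccc([N+](=O)[O-])cc1CSc1nc2cc(NC(=O)C3CCC3)ccc2n1C(C)C` gives 630 nM. Compound 3 `CCCn1c(SCc2cc([N+](=O)[O-])ccc2OC)nc2cc(NC(=O)NC(C)(C)C)cc(C(=O)OC)c21` gives 280 nM, the second highest of the three numbers; its gap to compound 1 is within the scatter, so no order can be read between those two, while its gap to compound 2 lies beyond the scatter, compound 2 showing the higher number. No two of these compounds differ in only one place, so no single step between measured compounds can be drawn from them.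

Compound 4 `CCCn1c(SCc2cc([N+](=O)[O-])ccc2OC)nc2cc(NC(=O)NC(C)(C)C)cc(C(=O)NCc3ccncc3)c21` is not yet measured. It differs from compound 3 in one place: ((pyridin-4-yl)methyl)amino in place of methoxy on a carbonyl carbon. Everything else in the structure is kept. Going by the values given here, no measured pair isolates a change at this carbonyl carbon, so the expectation rests on the narrow spread of the series alone. The step from compound 3 to compound 4 in this assay is expected to be small, in either direction, and probably not beyond the scatter; the estimated step is a 1.3-fold lower number from compound 3 to compound 4 (0.10 log units; within the scatter). For compound 4 the estimate in this assay is 220 nM, with a range from 60 nM to 800 nM.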

Compound 4, half-maximal inhibitory concentration: 35 nM
Beside the measured number, compound 4's estimate is 6.3-fold (0.80 log units) above it, outside the stated range (below it).
By their numbers in this assay, from the lowest: compound 4; then compounds 1 and 3 (each within the scatter of the next); then compound 2.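

In this assay, going by these compounds alone, the step at this carbonyl carbon is an 8.0-fold lower number from compound 3 to compound 4 (0.90 log units; beyond the scatter) and lies beyond the scatter, making it the first change at a single place that can be read. The position therefore accepts a much larger group, with 8 heavy atoms entering and 2 leaving, and the number falls rather than rises. The change also brings in an amide hydrogen and a six-membered aromatic ring with 1 hetero atom, but nothing measured here explains why the step runs in this direction.

Within the data shown here, the single step does not show which part of the ((pyridin-4-yl)methyl)amino group accounts for the lower number: the amide hydrogen, the one-carbon link or the pyridine ring with its nitrogen. A plain methylamino group, a benzylamino group and a (pyridin-3-yl)methylamino group on the same carbonyl carbon would begin to separate these parts, while a free carboxylic acid there would show how much depends on replacing the methoxy at all.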